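A Fluoro-Methoxyphenyl Variant on a Trimethoxyphenyl Pyrazolopyrimidine Core

The compounds below may be only part of what the source reports. "The series", "measured", "known", "first", "only" and "open" are said of these compounds alone.

Compound 1 `COc1cc(-c2ccnc3cc(-c4ccc(C)c(C)c4)nn23)cc(OC)c1OC` is the reference point of this small set. In a functional assay on B16-F0 cells (Mus musculus) for inhibition, read by CCK-8 assay, with a stated time of 48 h (a lower number here means a stronger inhibitor, a higher number a weaker inhibitor), compound 1 gives 391 nM, the lowest number among the three measured compounds. Compound 2 `COc1cc(-c2ccnc3cc(-c4ccccc4)nn23)cc(OC)c1OC` carries a bare phenyl in place of the 3,4-dimethylphenyl, and in this assay compound 2 gives 4730 nM. Compound 3 `COc1cc(-c2ccnc3cc(-c4ccc5cnn(C)c5c4)nn23)cc(OC)c1OC` carries a 1-methyl-1H-indazol-6-yl at the same position, and in this assay compound 3 gives 1000 nM.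

Compound 4 `COc1ccc(-c2cc3nccc(-c4cc(OC)c(OC)c(OC)c4)n3n2)cc1F` has not yet been measured. Relative to compound 1 the change is 3-fluoro-4-methoxyphenyl in place of 3,4-dimethylphenyl on an aromatic carbon. Going by the values given here, two measured steps bear on this: a 12-fold higher number from compound 1 to compound 2 (1.08 log units; beyond the scatter), and a 2.6-fold higher number from compound 1 to compound 3 (0.41 log units; beyond the scatter). Both replacements of the 3,4-dimethylphenyl raised the number, strongly when the ring lost its substituents altogether and modestly when a different substituted ring was put in. Among the compounds with values here, the new group keeps a substituted six-membered ring of carbon only, so a modest rise rather than a large one is the more likely outcome, though no measured compound carries this exact group.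

For compound 4 the expected step is a 2.0-fold higher number from compound 1 to compound 4 (0.31 log units; beyond the scatter). Compound 4 is therefore estimated to give about 800 nM, with a range from 300 nM to 2500 nM.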

Compound 4, half-maximal inhibitory concentration: 3950 nM
Compound 4: the middle estimate sits 4.9-fold (0.69 log units) below what was measured; the measured number lies above the stated range.
By their numbers in this assay, from the lowest: compound 1; then compound 3; then compounds 4 and 2 (each within the scatter of the next).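

In this assay the replacement gives a 10-fold higher number from compound 1 to compound 4 (1.00 log units; beyond the scatter) and so shows that keeping a substituted six-membered ring of carbon only at this position does not by itself preserve the low number of compound 1. The substituents of compound 4 leave it within the scatter of the bare phenyl of compound 2, with a 1.2-fold lower number from compound 2 to compound 4 (0.08 log units; within the scatter) on record, while the 1-methyl-1H-indazol-6-yl of compound 3 keeps its advantage, as a 4.0-fold higher number from compound 3 to compound 4 (0.60 log units; beyond the scatter) makes plain, so among these four compounds the presence of substituents alone does not sort the numbers. Nothing measured here accounts for the size of this loss.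

As far as these compounds go, what remains open is how the two changes within the new group divide the effect, since 4-methoxyphenyl and 3-fluorophenyl would separate the methoxy group from the fluorine. Equally open, from the compounds shown here alone, is whether either methyl of the 3,4-dimethylphenyl carries the low number alone, which 3-methylphenyl and 4-methylphenyl would address, and whether an ethyl or an amine in that place would be tolerated.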